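Methoxymethyl in place of pyridin-3-yl on a shared core

The compounds below may be only part of what the source reports. "The series", "measured", "known", "first", "only" and "open" are said of these compounds alone.

Compound 1, `Cn1c(-c2cccnc2)nc2ccc(-c3ccccc3Cl)c(CN)c21`, gives 0.433 h in an in vitro ADME assay on microsomes from liver (Rattus norvegicus) for metabolic stability; on this read-out higher numbers stand for a longer-lived compound and lower numbers for a shorter-lived compound.
Compound 2, `Cn1cnc2ccc(-c3ccccc3CO)c(CN)c21`, gives 0.65 h in this assay.
Compound 3, `Cn1cnc2cc(Br)c(-c3ccccc3Cl)c(CN)c21`, gives 0.4 h in this assay.

The three measured compounds share a core and differ in the groups attached to it. On this assay all three numbers lie close together: the gap from compound 1 to compound 3 and the gap from compound 1 to compound 2 each fall within the usual scatter of this kind of measurement, so compound 1 cannot be set apart from either of them on this read-out.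

Compound 4, `COCc1nc2ccc(-c3ccccc3Cl)c(CN)c2n1C`, has not yet been measured. It differs from compound 1 in one place:

methoxymethyl in place of pyridin-3-yl on an aromatic carbon

Among the compounds with values here, no pair of measured compounds shows what this particular change does, so the expectation for compound 4 rests only on the narrow spread of the three measured values. With nothing pointing up or down, the step of a 1.2-fold higher number from compound 1 to compound 4 (0.06 log units; within the scatter) is expected to stay within the scatter rather than move the number in either direction. For compound 4 the estimate in this assay is 0.5 h, with a range from 0.25 h to 1 h.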

Compound 4, half-life: 0.183 h
Compound 4: middle estimate off by 2.7-fold (0.44 log units), on the high side, and the stated range ends above it.
By their numbers in this assay, from the lowest: compound 4; then compounds 3, 1 and 2 (each within the scatter of the next).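

Within the data shown here, this position, an aromatic carbon between two ring nitrogen atoms, is not a neutral place for change in this assay: methoxymethyl in place of pyridin-3-yl gives a 2.4-fold lower number from compound 1 to compound 4 (0.37 log units; beyond the scatter), the only step here that is beyond the scatter. The close grouping of the earlier numbers therefore did not mean that any group could sit here with little effect on the read-out. The two groups match in their counts of hydrogen-bond donors and acceptors and neither carries a net charge, so those counts do not separate them, and nothing available explains the lower number.

A single step cannot show whether the ring that leaves, the oxygen of the methoxymethyl group or the shorter chain-like shape of the new group goes with the change, and a phenyl ring, a pyridin-4-yl ring or a plain ethyl chain at this position would help to pull these apart. On these data alone, it also remains open whether the same swap would give a step of similar size on a core carrying a different group elsewhere, such as the hydroxymethyl-bearing ring of compound 2.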